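Replacing a succinate ester with an allyl ether

The compounds below may be only part of what the source reports. "The series", "measured", "known", "first", "only" and "open" are said of these compounds alone.

Measured compounds:
compound 1, `Cc1c(C)c2c(c(C)c1OC(=O)CCC(=O)O)CCC(C)(COc1ccc(/C=C3\SC(=O)NC3=O)cc1)O2`: 76%
compound 2, `CC(C)=CCOc1c(C)c(C)c2c(c1C)CCC(C)(COc1ccc(/C=C3\SC(=O)NC3=O)cc1F)O2`: 64%
compound 3, `COc1cc(/C=C2\SC(=O)NC2=O)ccc1OCC1(C)CCc2c(C)c(OCC=C(C)C)c(C)c(C)c2O1`: 54%

In a functional assay on MCF7 cells (Homo sapiens), tested at 7.5 uM (on this read-out higher numbers stand for a weaker effect at the one concentration tested and lower numbers for a stronger effect), compound 1 gives 76%, the highest of the three numbers, so the weakest effect at the tested concentration. Compound 2 gives 64% and compound 3 gives 54%, both lower than compound 1 by more than the scatter. For the measured compounds named here, the only single-place step among the measured compounds, a number 10 percentage points lower from compound 2 to compound 3 (within the scatter), concerns a substituent on the aromatic ring bearing the benzylidene and stays within the scatter.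

Compound 4, `C=CCOc1c(C)c(C)c2c(c1C)CCC(C)(COc1ccc(/C=C3\SC(=O)NC3=O)cc1)O2`, differs from compound 1 in one place: allyl in place of (2-carboxyethyl)carbonyl on an oxygen on an aromatic ring. Going by the values given here, no measured step changes the group on that oxygen, so no step bears directly on it. What the data do show is that compounds 2 and 3, which carry an ether at that oxygen instead of the acyl group of compound 1, both give lower numbers than compound 1, though their ether is a prenyl group rather than an allyl group and their benzylidene ring carries an extra substituent.

The estimate for compound 4 is therefore a moderately lower number than compound 1, a step of a number 14 percentage points lower from compound 1 to compound 4 (beyond the scatter), with compound 4 expected at 62%, between 48% and 78%.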

Compound 4, a percentage reported as activity, at one concentration (the size of the read-out at that concentration, not a potency): 2%
Estimate against measurement, compound 4: 60 percentage points above, and the stated range ends above it.
By their numbers in this assay, from the lowest: compound 4; then compounds 3 and 2 (each within the scatter of the next); then compound 1.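

In this assay, the group on the oxygen on an aromatic ring proves decisive for the read-out: allyl in place of (2-carboxyethyl)carbonyl gives a step of (a number 74 percentage points lower from compound 1 to compound 4 (beyond the scatter)), which means a far stronger effect at the one concentration tested. The earlier single-place step, (a number 10 percentage points lower from compound 2 to compound 3 (within the scatter)), concerned methoxy in place of fluoro on an aromatic carbon, so it said nothing about how much this oxygen's substituent could matter. No measurement shown here explains why the change has such a large effect.

The replacement removes the ester carbonyl and the carboxylic acid end together while also introducing the allyl double bond, so the compounds shown cannot tell which of these changes carries the step. A free hydroxyl, a methyl ether, a saturated propyl ether or a carboxylic acid attached through an ether on this same oxygen, with the rest of compound 4 unchanged, would separate those contributions and show whether the allyl group itself is needed.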